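A few compounds are considered here, and "the series" means these few. Any claim that something is new, unique, unknown or untested is made for them only; others in the source may bear on it.

In a functional assay on HEL cells (Homo sapiens) for cytotoxicity (on this read-out lower numbers stand for higher toxicity in this test and higher numbers for lower toxicity in this test), compound 1 (`CO[C@@H]1[C@@H](OC)[C@H](Cc2ccccc2)O[C@@H]2CO[C@@H](c3ccccc3)O[C@@H]12`) gives > 50 ug/mL as its reading, which is a limit of the assay and not a number. Compound 2 (`CO[C@@H]1[C@@H](OC)[C@H](c2ccccc2)O[C@@H]2CO[C@@H](Cc3ccccc3)O[C@@H]12`) has "not determined" (no result reported) as its entry. Compound 3 (`CO[C@@H]1[C@@H](OC)[C@H](c2ccccc2)O[C@@H]2CO[C@@H](c3ccc(C)cc3)O[C@@H]12`) has "not determined" (no result reported) as its entry, so compound 3 stands on no number at all. Compound 4 (`CO[C@@H]1[C@@H](OC)[C@H](c2ccccc2)O[C@@H]2CO[C@@H](c3ccc(-c4ccccc4)cc3)O[C@@H]12`) is still to be measured. The change, phenyl in place of methyl on an aromatic carbon, para to a large group, counts as follows (phenyl in place of methyl on an aromatic carbon). Among the compounds with values here, no measured pair shows what a single change does in this assay readings, so no step beyond the usual scatter is expected, in either direction. Within the data shown here, the only guide is compound 1 with its limit of > 50 ug/mL as the sole reading. The expected value for compound 4 is an estimated 50 ug/mL within a range from 20 ug/mL to 100 ug/mL as the likely span.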

Compound 4, half-maximal cytotoxic concentration: > 50 ug/mL
Compound 4: no number, only a limit; the forecaster's own chance of this, stated with the estimate: 70%; the middle value lies on the limit itself.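

Compound 4 gives > 50 ug/mL, a limit of the assay and not a number. Within the data shown here, compound 3 has no number to compare, so no step between compound 3 and compound 4 can be read. From the compounds shown here alone, whether phenyl in place of methyl changes toxicity to these cells stays open.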